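The source may report more compounds than this note shows. Statements on the series, on what has been measured and on what is new or still open speak of the compounds shown alone.

Working notes on the series, read in an in vivo ADME assay on the whole organism (strain 129/SvEvBrd x C57BL/6) for pharmacokinetics, with Mus musculus as the target; on this read-out lower numbers stand for lower oral bioavailability and higher numbers for higher oral bioavailability. Compound 1 `CN(C)C(=O)c1nc([C@@H](O)[C@H](O)[C@H](O)CO)c[nH]1` gives 5%, compound 2 `OC[C@@H](O)[C@@H](O)[C@H](O)c1c[nH]c(-c2cscn2)n1` gives 12%, and compound 3 `OC[C@@H](O)[C@@H](O)[C@H](O)c1c[nH]c(-c2ncc[nH]2)n1` gives 28%, the highest of the three numbers. Both steps ending at that top value lie beyond the scatter: a number 23 percentage points higher from compound 1 to compound 3 (beyond the scatter) and a number 16 percentage points higher from compound 2 to compound 3 (beyond the scatter). By contrast, a number 7 percentage points higher from compound 1 to compound 2 (within the scatter) stays within it.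

The next change leads to compound 4 `OC[C@@H](O)[C@@H](O)[C@H](O)c1c[nH]c(-c2cnccn2)n1`: pyrazin-2-yl in place of 1H-imidazol-2-yl on an aromatic carbon. In words, pyrazin-2-yl stands in place of 1H-imidazol-2-yl on an aromatic carbon, between two ring nitrogen atoms, while the rest of the molecule stays the same.

Among the compounds with values here, the closest guide is the one measured swap of one aromatic ring for another at this place, a number 16 percentage points higher from compound 2 to compound 3 (beyond the scatter), read here in reverse as a move away from 1H-imidazol-2-yl. Within the data shown here, no measured compound carries a six-membered aromatic ring at this place, so the reading is indirect and the range must stay wide. A downward step smaller than that one is expected, and it may not clear the scatter. The expected step is a number 8 percentage points lower from compound 3 to compound 4 (within the scatter). In this assay, compound 4 is estimated at 20%, with an expected range of 7% to 36%.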

Compound 4, oral bioavailability: 10%
For compound 4 the middle estimate is 10 percentage points above the measured one; the measured number falls inside the stated range.
By their numbers in this assay, from the lowest: compounds 1, 4 and 2 (each within the scatter of the next); then compound 3.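

In this assay, a number 18 percentage points lower from compound 3 to compound 4 (beyond the scatter) shows that the higher number of compound 3 does not carry over to every aromatic ring with 2 hetero atoms on this aromatic carbon between two ring nitrogen atoms. With a number 2 percentage points lower from compound 2 to compound 4 (within the scatter) and a number 5 percentage points higher from compound 1 to compound 4 (within the scatter), the pyrazin-2-yl, 1,3-thiazol-4-yl and dimethylcarbamoyl compounds do not separate, so among these four compounds only the 1H-imidazol-2-yl group of compound 3 stands apart. The change from compound 3 to compound 4 alters ring size and hydrogen-bond donor count together, from a five-membered ring with 1 donor to a six-membered ring with 0 donors, and no supporting data on hand bear on the drop.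

The compounds shown leave open whether the ring size or the ring hydrogen-bond donor goes with the number of compound 3, a question that 1-methyl-1H-imidazol-2-yl, with a five-membered ring and no ring hydrogen, or 1H-pyrazol-3-yl, with a differently placed ring nitrogen, would address. Also open, on these data alone, is how a non-aromatic group at this place, such as a carboxylic acid or an amine, would read in this assay.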